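A few compounds are considered here, and "the series" means these few. Any claim that something is new, unique, unknown or untested is made for them only; others in the source may bear on it.

Measured in a functional assay on CHO cells (Homo sapiens) for antiproliferative activity against CHO (Cricetulus griseus), read by sulforhodamine B assay, with a stated time of 48 h; a lower number here means a stronger inhibitor, a higher number a weaker inhibitor:
- compound 1 `CCc1cccc(NS(=O)(=O)c2ccc(N3CCNC3=O)cc2)c1`: 230 nM
- compound 2 `COc1cc(NS(=O)(=O)c2ccc(N3CCNC3=O)cc2)cc(OC)c1OC`: 190 nM

Only these two values are available, and they lie within the scatter of each other, so compound 1 stands level with compound 2. Within the data shown here, the two differ in the group on the sulfonamide nitrogen, and no comparison between measured compounds isolates a single change.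

Compound 3 `Cc1cc(C)cc(NS(=O)(=O)c2ccc(N3CCNC3=O)cc2)c1` has not been measured. Relative to compound 1, it has 3,5-dimethylphenyl in place of 3-ethylphenyl on a sulfonamide nitrogen. The total carbon count of this group stays the same, and only its arrangement changes.

Compound 2 gives 190 nM with a quite different group in that place, which gives no reason to expect a large shift in this assay. The expected 1.2-fold lower number from compound 1 to compound 3 (0.06 log units; within the scatter) is no step beyond the scatter, and its direction is open. The estimate for compound 3 is 200 nM, with an expected range of 80 nM to 500 nM.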

Compound 3, half-maximal inhibitory concentration: 210 nM
The estimate for compound 3 lay 1.1-fold (0.02 log units) below the measured number, within the range that was stated.
By their numbers in this assay, from the lowest: compounds 2, 3 and 1 (each within the scatter of the next).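

In this assay, 3,5-dimethylphenyl in place of 3-ethylphenyl on the sulfonamide nitrogen gives a 1.1-fold lower number from compound 1 to compound 3 (0.04 log units; within the scatter). Among these compounds, this is the first comparison that isolates a single place, and it shows that redistributing the same carbon count on the aromatic ring does not separate the two compounds in this assay. Nothing measured bears on why the two groups read alike.

As far as these compounds go, it remains open whether the number on the sulfonamide nitrogen would hold with an amine or a carboxylic acid on the aromatic ring, or with a longer alkyl chain in place of the ring. The shared core is the same in all the compounds shown, so the contribution of its parts also remains open.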